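Chloro to fluoro at the edge of the assay

A few compounds are considered here, and "the series" means these few. Any claim that something is new, unique, unknown or untested is made for them only; others in the source may bear on it.

Compound 2 `S=C(SCc1cn(Cc2ccccc2Cl)nn1)N1CCNCC1` is examined in a functional assay on ECa-109 cells (Homo sapiens) for inhibition, read by MTT assay, with a stated time of 72 h; on this read-out higher numbers stand for weaker inhibition and lower numbers for stronger inhibition. In this assay compound 2 gives > 128000 nM, which is a limit of the assay and not a number. Compound 1 `Fc1ccc(Cn2cc(CSC(=S)N3CCNCC3)nn2)cc1` likewise sits at a limit, giving > 128000 nM in this assay. The step from compound 1 to compound 2 (a step that the two limits leave unreadable from compound 1 to compound 2) is therefore unreadable, and both values rest at the limit of > 128000 nM in this assay, at which 2 of the 2 values shown sit. Compound 3 `Fc1ccccc1Cn1cc(CSC(=S)N2CCNCC2)nn1` differs from compound 2 by fluoro in place of chloro on an aromatic carbon. For the measured compounds named here, no measured step reads on this change, so no step beyond the scatter is expected. The step from compound 2 to compound 3 is estimated as a number no higher from compound 2 to compound 3 (the limit leaves the size open). Compound 3 is therefore expected to give about 128000 nM in this assay, within 40000 nM to 400000 nM, most likely again only as a limit.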

Compound 3, half-maximal inhibitory concentration: > 128000 nM
Compound 3: no number, only a limit; the forecaster's own chance of this, stated with the estimate: 80%; the middle value lies on the limit itself.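

No step can be read among compound 1, compound 2 and compound 3, since each gives only a limit and not a number: the limit of > 128000 nM in this assay, at which 3 of the 3 values shown sit. From the compounds shown here alone, what fluoro in place of chloro does to inhibition in this assay stays open, as does any ranking of the three compounds.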